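This account rests on a few compounds, and the source may have more. Where it says the series, first, only, none or still open, it means among the compounds named here.

Measured in a functional assay on HepG2 cells (Homo sapiens) for cytotoxicity, with a stated time of 72 h; on this read-out lower numbers stand for an effect already at smaller amounts and higher numbers for an effect only at larger amounts of compound:
- compound 1 `C=C[C@@](C)(/C=C/c1ccc(Nc2ccc(OC)cc2)cc1)CCC=C(C)C`: > 52000 nM
- compound 2 `C=C[C@@](C)(/C=C/c1ccc(-c2ccccc2)cc1)CCC=C(C)C`: > 52000 nM

Compound 2 gives > 52000 nM, which is a limit of this assay and not a number. Compound 1 gives > 52000 nM, also a limit. Compound 3 `C=C[C@@](C)(/C=C/c1ccc(-c2cccc(Br)c2)cc1)CCC=C(C)C` has bromo in place of hydrogen on an aromatic carbon, turning phenyl to 3-bromophenyl: bromo in place of hydrogen on an aromatic carbon.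

For the measured compounds named here, only one measured step bears on this change, a step that the two limits leave unreadable from compound 1 to compound 2, and it has no readable size. It involves a different change, so it offers no size to carry over. Going by the values given here, the sole guide is the position of the series: the limit of > 52000 nM in this assay, at which 2 of the 2 values shown sit. No step beyond the scatter is therefore expected in this assay, and no direction can be argued, with a reported limit again being the likeliest outcome.

The estimate corresponds to an expected at least 1.0-fold lower number from compound 2 to compound 3 (0.03 log units; that floor lies within the scatter). For compound 3 the expected value is 48000 nM, with an estimated range of 15000 nM to 70000 nM.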

Compound 3, half-maximal effective concentration: > 52000 nM
Compound 3: no number, only a limit; the forecaster's own chance of this, stated with the estimate: 65%; middle value at least 1.0-fold (0.03 log units) away from the limit.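

No step can be read between compound 1, compound 2 and compound 3 in this assay, as all results are limits and not numbers: the limit of > 52000 nM in this assay, at which 3 of the 3 values shown sit.

The compounds shown leave open whether bromo in place of hydrogen has any effect in this assay, and whether any compound with this core gives a number there.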